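Pyridin-4-yl in place of 4-cyanophenyl on the shared core

A few compounds are considered here, and "the series" means these few. Any claim that something is new, unique, unknown or untested is made for them only; others in the source may bear on it.

Compound 1 `Cc1ccc(Cn2ccc3nc(-c4ccccc4)nc-3c2)cc1` reaches only the limit in an ADME assay on MDBK cells (Bos taurus) for cytotoxicity (on this read-out lower numbers stand for higher toxicity in this test and higher numbers for lower toxicity in this test), where compound 1 gives > 100000 nM. Compound 2 `COc1cccc(Cn2ccc3nc(-c4ccccc4)nc-3c2)c1` likewise gives only the limit, > 100000 nM. Compound 3 `N#Cc1ccc(Cn2ccc3nc(-c4ccccc4)nc-3c2)cc1` also gives only the limit, > 100000 nM, so its standing among the values shown is fixed only by the limit of > 100000 nM in this assay, at which 3 of the 3 values shown sit. The change to compound 4 `c1ccc(-c2nc3ccn(Cc4ccncc4)cc-3n2)cc1` is pyridin-4-yl in place of 4-cyanophenyl on a saturated chain carbon bound to an aromatic nitrogen. The measured steps that touch compound 3 are a step that the two limits leave unreadable from compound 1 to compound 3 and a step that the two limits leave unreadable from compound 2 to compound 3; neither has a readable size, and a step that the two limits leave unreadable from compound 1 to compound 2 is equally unreadable. Among the measured compounds shown here, no step of known size therefore supports an expectation of movement beyond the scatter, and the expected outcome for compound 4 is again a limit. The expected step is a number no higher from compound 3 to compound 4 (the limit leaves the size open). Compound 4 is estimated at 100000 nM, between 40000 nM and 300000 nM.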

Compound 4, half-maximal cytotoxic concentration: > 100000 nM
Compound 4 gave a limit, no number; the forecaster's own chance of this, stated with the estimate: 85%; the middle value lies on the limit itself.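

In this assay, among the compounds shown here, compound 4, like compound 1, compound 2 and compound 3, gives only a limit, so no step among them can be read: the limit of > 100000 nM in this assay, at which 4 of the 4 values shown sit.
The compounds shown leave open whether any group at this place on the shared core gives a measurable half-maximal cytotoxic concentration.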